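The compounds below may be only part of what the source reports. "The series", "measured", "known", "first", "only" and "open" are said of these compounds alone.

Measured in a functional assay on DU-145 cells (Homo sapiens) for inhibition, read by MTT assay, with a stated time of 24 h; on this read-out lower numbers stand for stronger inhibition and higher numbers for weaker inhibition:
compound 1 `CCOC(=O)C1=Cc2ccccc2OC1(OCc1cn(-c2ccc(F)c(Cl)c2)nn1)C(F)(F)F`: 21500 nM
compound 2 `CCOC(=O)C1=Cc2ccccc2OC1(OCc1cn(-c2cccc(C(F)(F)F)c2)nn1)C(F)(F)F`: a limit only, > 150000 nM
compound 3 `CCOC(=O)C1=Cc2ccccc2OC1(OCc1cn(CC(=O)NC2CCCCC2)nn1)C(F)(F)F`: 10200 nM

Compound 3 holds the lowest of the two numbers. The step of a 2.1-fold lower number from compound 1 to compound 3 (0.32 log units; beyond the scatter) is modest, and an at least 14-fold lower number from compound 2 to compound 3 (1.16 log units; beyond the scatter) is large, though it rests on the limit (the limit of > 150000 nM in this assay, at which 1 of the 3 values shown sits).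

Compound 4 `CCOC(=O)C1=Cc2ccccc2OC1(OCc1cn(CC(=O)Nc2cccc(Cl)c2)nn1)C(F)(F)F` differs from compound 3 by 3-chlorophenyl in place of cyclohexyl on an amide-type nitrogen. For the measured compounds named here, every measured step changes the group on the aromatic nitrogen of the triazole, and none touches the amide-type nitrogen, so no measured step bears on this change. The expected step of a 1.2-fold higher number from compound 3 to compound 4 (0.07 log units; within the scatter) is therefore none beyond the scatter. Compound 4 is estimated at 12000 nM, with a range from 4000 nM to 40000 nM.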

Compound 4, half-maximal inhibitory concentration: 10100 nM
For compound 4 the middle estimate is 1.2-fold (0.07 log units) above the measured one, and the stated range covers the measured number.
By their numbers in this assay, from the lowest: compounds 4 and 3 (each within the scatter of the next); then compound 1. At a limit, above all of these: compound 2.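

In this assay, for the compounds shown here, the first change at the amide-type nitrogen gives a 1.0-fold lower number from compound 3 to compound 4 (0.00 log units; within the scatter), so 3-chlorophenyl and cyclohexyl read alike at this position, one aromatic ring and one non-aromatic. On the aromatic nitrogen, ((3-chlorophenyl)carbamoyl)methyl also stands clear of 3-chloro-4-fluorophenyl, with a 2.1-fold lower number from compound 1 to compound 4 (0.33 log units; beyond the scatter), which shows that the gain seen with (cyclohexylcarbamoyl)methyl does not depend on cyclohexyl. Compound 2 has a limit only, so an at least 14-fold lower number from compound 2 to compound 4 (1.17 log units; beyond the scatter) is a bound and not a size: the limit of > 150000 nM in this assay, at which 1 of the 4 values shown sits.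

Open, going by these compounds, is whether unsubstituted phenyl on the amide-type nitrogen matches these two compounds. Also open, on these data alone, is whether a longer open carbon chain or a ring carrying an amine or a carboxylic acid holds the same level there.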